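The compounds below may be only part of what the source reports. "The series", "measured", "known", "first", "only" and "open" are said of these compounds alone.

Working notes on the adenosine deaminase series.

Of the compounds shown here, three sharing one core have numbers so far. Compound 1 `C[C@H](O)[C@@H](CCc1cccc(Br)c1)n1cnc2c(N)ncnc21` gives 0.6 nM in an assay on isolated protein for inhibition of adenosine deaminase (Bos taurus), with a stated time of 5 min; a lower number here means a stronger inhibitor, a higher number a weaker inhibitor. Compound 2 `COC(=O)c1cccc(CC[C@H]([C@H](C)O)n2cnc3c(N)ncnc32)c1` gives 2.2 nM in this assay, and compound 3 `CNC(=O)c1cccc(CC[C@H]([C@H](C)O)n2cnc3c(N)ncnc32)c1` gives 2.7 nM. The move from bromo to methoxycarbonyl on the aromatic carbon reads a 3.7-fold higher number from compound 1 to compound 2 (0.56 log units; beyond the scatter); the corresponding move to methylcarbamoyl reads a 4.5-fold higher number from compound 1 to compound 3 (0.65 log units; beyond the scatter). Between the two carbonyl-bearing compounds the exchange of methoxy for methylamino on the carbonyl carbon reads a 1.2-fold higher number from compound 2 to compound 3 (0.09 log units; within the scatter).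

Compound 3 therefore holds the highest of the three numbers; its nearest neighbour is compound 2, within the scatter, and its furthest is compound 1, beyond it.

Compound 4 `C[C@H](O)[C@@H](CCc1cccc(C(=O)NC2CCCC2)c1)n1cnc2c(N)ncnc21` differs from compound 3 by cyclopentyl in place of methyl on an amide-type nitrogen, that is, methylcarbamoyl becomes cyclopentylcarbamoyl. Within the data shown here, no measured step changes the substituent on the amide-type nitrogen. Among the measured compounds shown here, the only step that touches the same region, the methoxy to methylamino exchange, lay within the scatter; the larger steps in this assay arose from replacing bromo, not from altering the group on the carbonyl. On that basis a step of a 1.1-fold higher number from compound 3 to compound 4 (0.05 log units; within the scatter) is expected, most likely not beyond the scatter in either direction. Compound 4 is estimated at 3 nM in this assay, with a range of 1 nM to 10 nM.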

Compound 4, inhibition constant: 1.8 nM
For compound 4 the middle estimate is 1.7-fold (0.22 log units) above the measured one; the measured number falls inside the stated range.
By their numbers in this assay, from the lowest: compound 1; then compounds 4, 2 and 3 (each within the scatter of the next).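

Among these compounds, the substituent on the amide-type nitrogen is now varied for the first time: in this assay, cyclopentyl in place of methyl, with five heavy atoms entering for one and a five-membered non-aromatic ring added, gives a 1.5-fold lower number from compound 3 to compound 4 (0.18 log units; within the scatter), so this much added carbon at this position leaves the number within the scatter. The exchange of methoxy for cyclopentylamino on the carbonyl carbon, at a 1.2-fold lower number from compound 2 to compound 4 (0.09 log units; within the scatter), likewise stays within the scatter, which places the ester and both amides together, while the step from the bromo compound, a 3.0-fold higher number from compound 1 to compound 4 (0.48 log units; beyond the scatter), shows that compound 1 remains apart from all three carbonyl-bearing compounds, with each of its steps beyond the scatter. Nothing at hand bears on why the number tolerates this change at the amide-type nitrogen.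

Open, going by these compounds, is how far this tolerance extends on the amide-type nitrogen, for instance to a longer chain, a cyclohexyl ring or a chain ending in an amine. Also open, on these data alone, is how a carboxylic acid in place of the amide on the aromatic carbon would read in this assay.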